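Mirror-Image Change on a Urea Side Chain

The compounds below may be only part of what the source reports. "The series", "measured", "known", "first", "only" and "open" are said of these compounds alone.

Compound 3, `Cc1ccc(NC(=O)N[C@H](C)c2ccccc2)cc1`, was measured in an ADME assay on the whole organism with Oryza sativa as the target, tested at 0.1 uM (on this read-out lower numbers stand for a stronger effect and higher numbers for a weaker effect at the one concentration tested), and gave 100%. Two close relatives give numbers of the same size: compound 1, `Cc1ccccc1NC(=O)N[C@@H](C)c1ccccc1`, gives 100%, and compound 2, `Cc1cccc(NC(=O)N[C@@H](C)c2ccccc2)c1`, gives 99%. Compound 3 therefore sits level with compound 1 at the digits shown, the pair together the highest of the three numbers, with no change between them within the scatter, and its gap to compound 2 is also within the scatter. All three readings show essentially no effect on the rice plant at the one concentration tested.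

The next compound, compound 4, `Cc1ccc(NC(=O)N[C@@H](C)c2ccccc2)cc1`, has not been measured. the two compounds have the same atoms and bonds and differ only in configuration as drawn: 1 of 1 stereo elements differ; a stereocentre at a saturated chain carbon is drawn R in compound 3 and S in compound 4

Among the compounds with values here, nothing among the measured compounds separates the two drawn configurations, and every measured number lies near the top of the scale. The step from compound 3 to compound 4 in this assay is therefore expected to be none beyond the scatter, and compound 4 is estimated to give 99%, within a range from 90% to 100%, which means an expected step of a number 1 percentage points lower from compound 3 to compound 4 (within the scatter).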

Compound 4, a percentage reported as activity, at one concentration (the size of the read-out at that concentration, not a potency): 100%
For compound 4 the middle estimate is 1 percentage points below the measured one, within the range that was stated.
By their numbers in this assay, from the lowest: compounds 2, 1, 3 and 4 (each within the scatter of the next).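

In this assay, the mirror-image pair gives no change at the digits printed from compound 3 to compound 4 (within the scatter). This is the first comparison among these compounds in which a single feature can be judged on its own, and the step can be tied to the stereocentre at the saturated chain carbon alone because of what separates the pair: the fact that compounds 3 and 4 differ only in the configuration as drawn. For this pair, then, swapping R for S at that carbon leaves the read-out unmoved, although both numbers lie near the top of the scale, where the compounds show essentially no effect, so the pair says nothing about the role of configuration in a compound with a clear effect.

The compounds shown leave open whether a carboxylic acid or an amine on the ring, or a longer chain at the stereocentre, would bring the number down. They also leave open whether the two configurations would then give different numbers.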